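From compound 1 to compound 3: a larger side group

The source may hold more compounds than are shown below. What is called first, only, known or untested is meant among the compounds shown, and "the series" means these compounds.

- Compound 1 (`COc1ccc(-c2cc(=O)c3ccc(OCCCN4CCC(CCO)CC4)cc3o2)cc1`) gives 22.8 nM
- Compound 2 (`COc1ccc(-c2cc(=O)c3ccc(OCCCCCN4CCC(C)CC4)cc3o2)cc1`) gives 31.7 nM

Both numbers come from a functional assay, read by spectrophotometry (on this read-out lower numbers stand for an effect already at smaller amounts and higher numbers for an effect only at larger amounts of compound), and lie within the usual scatter of each other, so compound 1 stands level with compound 2. Among the compounds with values here, compound 3 (`COc1ccc(-c2cc(=O)c3ccc(OCCCCCN4CCC(CCO)CC4)cc3o2)cc1`) keeps the core of compound 1 and differs in one place: a group of 11 heavy atoms (9 carbon, 1 nitrogen, 1 oxygen; one six-membered non-aromatic ring with 1 hetero atom) in place of a group of 9 heavy atoms (7 carbon, 1 nitrogen, 1 oxygen; one six-membered non-aromatic ring with 1 hetero atom), on a saturated chain carbon, three bonds along the chain from an oxygen on an aromatic ring (the only structural change). Just one measured step touches that same place on the chain (a 1.4-fold higher number from compound 1 to compound 2 (0.14 log units; within the scatter)), and it is small. Within the data shown here, it is thin evidence, since no measured pair shows this exact swap. On that basis, no step beyond the scatter is expected in this assay in either direction. The estimated change is therefore small (a 1.2-fold higher number from compound 1 to compound 3 (0.07 log units; within the scatter)). For compound 3 the expected value is 27 nM (estimated range 11 nM to 65 nM).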

Compound 3, half-maximal effective concentration: 27.9 nM
The estimate for compound 3 lay 1.0-fold (0.01 log units) below the measured number, within the range that was stated.
By their numbers in this assay, from the lowest: compounds 1, 3 and 2 (each within the scatter of the next).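

In this assay, the larger group of 11 heavy atoms at this place on the chain leaves the read-out level, with a 1.2-fold higher number from compound 1 to compound 3 (0.09 log units; within the scatter). Compound 3 also adds a second measured swap: hydroxymethyl in place of hydrogen on a saturated chain carbon bound to a saturated ring carbon gives a 1.1-fold lower number from compound 2 to compound 3 (0.06 log units; within the scatter), so at this stage neither change separates the compounds, and this place tolerates both swaps without a step beyond the scatter. No supporting measurement is available that could explain this flat result.

The three compounds shown say nothing about how a carboxylic acid or an amine in place of the hydroxyl would read in this assay. As far as these compounds go, a much longer chain also remains open, as does whether any change here can produce a step beyond the scatter.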